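The source may report more compounds than this note shows. Statements on the series, on what has been measured and on what is new or still open speak of the compounds shown alone.

Measured in a functional assay on HeLa cells (Homo sapiens) for cytotoxicity, read by MTT assay, with a stated time of 24 h; a lower number here means a stronger inhibitor, a higher number a weaker inhibitor:
compound 1 `CNC(=O)Cn1nc(N)c2c(C(F)(F)F)cc(-c3ccccc3)nc21` gives 12200 nM
compound 2 `NCCNC(=O)Cn1nc(N)c2c(C(F)(F)F)cc(-c3ccccc3)nc21` gives 44500 nM

Compound 1 stands at the lowest of the two numbers. Within the data shown here, the single measured step, a 3.6-fold higher number from compound 1 to compound 2 (0.56 log units; beyond the scatter), moves away from it with aminomethyl in place of hydrogen on a saturated chain carbon bound to an amide-type nitrogen.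

Compound 3 `Nc1nn(CC(=O)NCC(=O)O)c2nc(-c3ccccc3)cc(C(F)(F)F)c12` has not yet been measured in this assay. It differs from compound 1 by carboxy in place of hydrogen on a saturated chain carbon bound to an amide-type nitrogen. Among the measured compounds shown here, the only measured step that bears on this is the one from compound 1 to compound 2: the same place, a group entering where hydrogen sat, and a modest move to a higher number. For the measured compounds named here, on that single comparison, a carboxy group at the same position is expected to move the number the same way and by a similar modest margin, with considerable uncertainty since no second example exists.

Compound 3 is therefore expected at 28000 nM, with a range of 11000 nM to 75000 nM, the expected step being a 2.3-fold higher number from compound 1 to compound 3 (0.36 log units; beyond the scatter).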

Compound 3, half-maximal inhibitory concentration: 19100 nM
For compound 3 the middle estimate is 1.5-fold (0.17 log units) above the measured one, within the range that was stated.
By their numbers in this assay, from the lowest: compounds 1 and 3 (each within the scatter of the next); then compound 2.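

In this assay carboxy on a saturated chain carbon bound to an amide-type nitrogen gives a 1.6-fold higher number from compound 1 to compound 3 (0.19 log units; within the scatter) and so stays within the scatter of compound 1, whereas aminomethyl at the same place gave a 3.6-fold higher number from compound 1 to compound 2 (0.56 log units; beyond the scatter) and moved beyond it. Carboxy in place of aminomethyl gives a 2.3-fold lower number from compound 2 to compound 3 (0.37 log units; beyond the scatter) as a step of its own, so at this position the outcome depends on which group enters and not merely on a group replacing hydrogen. No measurement at hand bears on the reason for this difference.

On these data alone, what a longer chain ending in a carboxylic acid, the methyl ester of compound 3 or a hydroxymethyl group would do at this place stays open. Among these compounds, with only three compounds on one core, it is also open whether the gap between compound 2 and compound 3 would hold on another core.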